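Ethoxy for Methyl in a Series at the Assay Limit

The source may report more compounds than this note shows. Statements on the series, on what has been measured and on what is new or still open speak of the compounds shown alone.

Of the compounds shown here, three sharing one core have been tested in a functional assay on SW480 cells (Homo sapiens) for cytotoxicity, read by MTT assay, with a stated time of 24 h; on this read-out lower numbers stand for stronger inhibition and higher numbers for weaker inhibition. Compound 1 `C=CC1=C(C(=O)NCc2ccc(C)cc2)C(c2ccc(F)cc2)OC1` gives > 100000 nM, which is a limit of the assay rather than a number. Compound 2 `C=CC1=C(C(=O)NCc2ccc(Cl)cc2)C(c2ccc(F)cc2)OC1`, which differs only by chloro in place of methyl on an aromatic carbon, gives > 100000 nM, again a limit. Compound 3 `C=CC1=C(C(=O)Nc2ccc(C)cc2)C(c2ccc(F)cc2)OC1` carries 4-methylphenyl in place of 4-methylbenzyl on the amide-type nitrogen and gives > 100000 nM, also a limit. The steps between them, a step that the two limits leave unreadable from compound 1 to compound 2, a step that the two limits leave unreadable from compound 1 to compound 3 and a step that the two limits leave unreadable from compound 2 to compound 3, cannot be read, because all three values sit at the limit of > 100000 nM in this assay, at which 3 of the 3 values shown sit. Compound 3 therefore stands where every measured compound stands: at the edge of what this assay can report, with no number of its own.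

Compound 4 `C=CC1=C(C(=O)Nc2ccc(OCC)cc2)C(c2ccc(F)cc2)OC1` is the next compound to be tested in this assay. It differs from compound 3 by ethoxy in place of methyl on an aromatic carbon. Within the data shown here, no measured step touches this part of the structure, and the steps that are measured are all unreadable, so no size or direction can be drawn from them. The expectation is that the step that the limit leaves unreadable from compound 3 to compound 4 stays within what three limits allow, most likely ending in another limit. Compound 4 is thus expected to give about 150000 nM, in a range from 50000 nM to 500000 nM.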

Compound 4, half-maximal inhibitory concentration: > 100000 nM
Compound 4 gave a limit, no number; the forecaster's own chance of this, stated with the estimate: 75%; the middle value is on the limit's open side.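

In this assay compound 4 gives a limit, as compound 3 does, so the step between them cannot be read, and the same holds for every step involving compound 1 and compound 2: the limit of > 100000 nM in this assay, at which 4 of the 4 values shown sit.

The compounds shown leave open whether any change on this core brings a real number in this assay and how large these steps truly are.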